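This account rests on a few compounds, and the source may have more. Where it says the series, first, only, none or still open, it means among the compounds named here.

In a functional assay on A549 cells (Homo sapiens) for inhibition, read by MTT assay, with a stated time of 48 h (a higher number here means a weaker inhibitor, a lower number a stronger inhibitor), compound 3 `CCn1c(/C=C2\SC(=O)N(CC(=O)N3CC(C)OC(C)C3)C2=O)nc2ccccc21` gives > 50000 nM, which is a limit and not a number. Compound 1 `Cn1c(/C=C2\SC(=O)N(CC(=O)N3CCCCC3)C2=O)nc2ccccc21` gives > 50000 nM, also a limit. Compound 2 `Cn1c(/C=C2\SC(=O)N(CC(=O)N3CCCC3)C2=O)nc2ccccc21` gives > 50000 nM, again a limit. The change under review leads to compound 4 `CC1CN(C(=O)CN2C(=O)S/C(=C\c3nc4ccccc4n3C)C2=O)CC(C)O1`: hydrogen in place of methyl on a saturated chain carbon bound to an aromatic nitrogen, that is, ethyl to methyl. For the measured compounds named here, the one measured step is a step that the two limits leave unreadable from compound 1 to compound 2, a different change, and it gives no size to carry over. Starting from compound 3, no step beyond the scatter is expected in this assay, in either direction, because of the limit of > 50000 nM in this assay, at which 3 of the 3 values shown sit. The step expected is a step that the limit leaves unreadable from compound 3 to compound 4. For compound 4 the estimated value is 60000 nM, with an expected range of 25000 nM to 150000 nM.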

Compound 4, half-maximal inhibitory concentration: 29400 nM
The estimate for compound 4 lay 2.0-fold (0.31 log units) above the measured number; measured number inside the range.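

In this assay compound 4 is the only compound shown that gives a number, 29400 nM, and not a limit. Ethyl to methyl at the saturated chain carbon bound to an aromatic nitrogen gives an at least 1.7-fold lower number from compound 3 to compound 4 (0.23 log units; that floor lies within the scatter), while the two amide changes give an at least 1.7-fold lower number from compound 2 to compound 4 (0.23 log units; that floor lies within the scatter) and an at least 1.7-fold lower number from compound 1 to compound 4 (0.23 log units; that floor lies within the scatter). Each step is only a floor, because of the assay ceiling: the limit of > 50000 nM in this assay, at which 3 of the 4 values shown sit.

Open, going by these compounds, is whether a propyl or benzyl group on that aromatic nitrogen would give a readable number. Also open, on these data alone, is how a piperazine on the carbonyl carbon would read.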